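This account rests on a few compounds, and the source may have more. Where it says the series, first, only, none or still open, it means among the compounds named here.

Compound 1 `CCCC(C)Oc1ccc(C(=O)/C=C/c2c(/C=C/c3ccc(OC)cc3)cc(OC)cc2OC)cc1` in a functional assay on B16-F10 cells (Mus musculus) for antiproliferative activity, read by MTT assay, with a stated time of 48 h (on this read-out higher numbers stand for weaker inhibition and lower numbers for stronger inhibition), gives 6.7 ug/mL.
Compound 2 `COc1ccc(/C=C/c2cc(OC)cc(OC)c2/C=C/C(=O)c2ccc(C(F)(F)F)cc2)cc1` gives 4.3 ug/mL.
Compound 3 `COc1ccc(/C=C/c2cc(OC)cc(OC)c2/C=C/C(=O)c2ccccc2C)cc1` gives 6.1 ug/mL.

The three numbers sit close together. Compound 3 stands nearest to compound 1, the gap being a 1.1-fold lower number from compound 1 to compound 3 (0.04 log units; within the scatter), and furthest from compound 2, the gap being a 1.4-fold higher number from compound 2 to compound 3 (0.15 log units; within the scatter); both gaps lie within the scatter, so no ordering among the three can be read from them.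

Compound 4 `COc1ccc(/C=C/c2cc(OC)cc(OC)c2/C=C/C(=O)c2ccc(Br)cc2)cc1` has not yet been measured. It differs from compound 3 in one place: 4-bromophenyl in place of 2-methylphenyl on a carbonyl carbon. For the measured compounds named here, two measured steps bear on this change. The exchange of the aryl group on the carbonyl carbon, a 1.4-fold higher number from compound 2 to compound 3 (0.15 log units; within the scatter), stayed within the scatter, and the exchange of a substituent on an aromatic carbon of that same aryl group, a 1.6-fold lower number from compound 1 to compound 2 (0.19 log units; within the scatter), stayed within the scatter as well. Compound 4 is therefore expected to show a step of a 1.1-fold lower number from compound 3 to compound 4 (0.04 log units; within the scatter), which is no change beyond the scatter. The estimate for compound 4 is 5.5 ug/mL, within a range from 2.7 ug/mL to 11 ug/mL.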

Compound 4, half-maximal inhibitory concentration: 6.5 ug/mL
The estimate for compound 4 lay 1.2-fold (0.07 log units) below the measured number; the measured number falls inside the stated range.
By their numbers in this assay, from the lowest: compounds 2, 3, 4 and 1 (each within the scatter of the next).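

In this assay, 4-bromophenyl in place of 2-methylphenyl on the carbonyl carbon gave a step within the scatter (a 1.1-fold higher number from compound 3 to compound 4 (0.03 log units; within the scatter)), so a bromine-bearing aryl group now joins the others at this position with no readable change. Bromo in place of trifluoromethyl (a 1.5-fold higher number from compound 2 to compound 4 (0.18 log units; within the scatter)) and bromo in place of 1-methylbutoxy (a 1.0-fold lower number from compound 1 to compound 4 (0.01 log units; within the scatter)) read the same way, and no aryl group on the carbonyl carbon among these four compounds separates from another beyond the scatter. No measurement at hand accounts for why the numbers stay together.

As far as these compounds go, whether an amine or a carboxylic acid on that aryl group would move the number beyond the scatter remains open. From the compounds shown here alone, all four compounds keep the shared core, and what a change there would do is also open.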